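Extending the heptyl chain of compound 2 toward an amine-bearing octyl

The compounds below may be only part of what the source reports. "The series", "measured", "known", "first", "only" and "open" are said of these compounds alone.

The series shares one core carrying an amide on a sugar-like ring; the amide nitrogen bears a chain that varies. Compound 1 `CCCCCNC(=O)[C@H]1O[C@@H](n2cnc3c(N)ncnc32)[C@H](O)[C@@H]1O` carries a pentyl chain, compound 2 `CCCCCCCNC(=O)[C@H]1OC(n2cnc3c(N)ncnc32)[C@H](O)[C@@H]1O` a heptyl chain, and compound 3 `CC(C)(C)NC(=O)[C@H]1O[C@@H](n2cnc3c(N)ncnc32)[C@H](O)[C@@H]1O` a tert-butyl group. In an assay on cell membranes for binding affinity to 2-oxoglutarate receptor 1 (Rattus norvegicus), read by radioligand binding (on this read-out higher numbers stand for weaker inhibition and lower numbers for stronger inhibition), compound 1 gives 12 nM, compound 2 gives 20 nM, and compound 3 gives 6850 nM. Among these three numbers, compound 2 stands second highest; its value lies within the usual scatter of compound 1, whereas compound 3 lies far away from both. For the measured compounds named here, the only single-point step in the set, a 570-fold higher number from compound 1 to compound 3 (2.76 log units; beyond the scatter), shows how strongly branching at the nitrogen raises the number.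

Compound 4 `NCCCCCCCCNC(=O)[C@H]1OC(n2cnc3c(N)ncnc32)[C@H](O)[C@@H]1O` differs from compound 2 by aminomethyl in place of hydrogen on a saturated chain carbon, seven bonds along the chain from an amide-type nitrogen. Going by the values given here, no measured step addresses an amine at the far end of the chain; the step from pentyl to heptyl, seen in the values of compound 1 and compound 2, shows that chain length alone changes little, while the step from compound 1 to compound 3 concerns branching, not length, and so does not bear directly. The author therefore expects at most a modest change in this assay, without a firm direction, and estimates compound 4 at 40 nM with a range of 8 nM to 250 nM, a step of a 2.0-fold higher number from compound 2 to compound 4 (0.30 log units; within the scatter) from compound 2 that is expected rather than known.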

Compound 4, inhibition constant: 29 nM
Beside the measured number, compound 4's estimate is 1.4-fold (0.14 log units) above it; the measured number falls inside the stated range.
By their numbers in this assay, from the lowest: compounds 1, 2 and 4 (each within the scatter of the next, the first and the last beyond it); then compound 3.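

At the far end of the chain, seven bonds along the chain from an amide-type nitrogen, aminomethyl in place of hydrogen gives a 1.5-fold higher number from compound 2 to compound 4 (0.16 log units; within the scatter) in this assay and so leaves compound 2 and compound 4 indistinguishable on this read-out. For the compounds shown here, the earlier compounds carried only plain hydrocarbon groups on the amide nitrogen, so they could not show that a chain ending in an amine stays within the scatter of the heptyl chain, a very different outcome in size from the branching step, a 570-fold higher number from compound 1 to compound 3 (2.76 log units; beyond the scatter), which was the only single-point change known before. Nothing available here accounts for this result.

The compounds shown leave open whether the amine itself matters at this chain end, since a hydroxyl, a carboxylic acid or a still longer chain in the same place would be needed to tell that. They also leave open whether an amine would be accepted on the shorter pentyl chain of compound 1, or on a branched chain like the tert-butyl group of compound 3.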